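The compounds below may be only part of what the source reports. "The series", "measured", "known", "first", "only" and "open" are said of these compounds alone.

Compound 1 `Cc1ccc(S/C(=C/c2ccc(Br)cc2)C(=O)c2ccc(Cl)cc2)cc1` gives 25000 nM in a functional assay on DU-145 cells (Homo sapiens) for inhibition, read by trypan blue exclusion, with a stated time of 96 h; on this read-out lower numbers stand for stronger inhibition of growth and higher numbers for weaker inhibition of growth.
Compound 2 `O=C(/C(=C\c1ccc(Br)cc1)SCc1ccc(Cl)cc1)c1ccc(Cl)cc1` gives 1000 nM in this assay.
Compound 3 `O=C(/C(=C\c1ccc(Br)cc1)SCc1ccc(F)cc1)c1ccc(Cl)cc1` gives 9000 nM in this assay.

Compound 2 stands lowest of the three, separated from the others by a 25-fold lower number from compound 1 to compound 2 (1.40 log units; beyond the scatter) and a 9.0-fold higher number from compound 2 to compound 3 (0.95 log units; beyond the scatter), both beyond the scatter. Compound 4 `COc1ccc(/C=C(/SCc2ccc(Cl)cc2)C(=O)c2ccc(Cl)cc2)cc1` keeps the core of compound 2 and differs in one place: methoxy in place of bromo on an aromatic carbon. For the measured compounds named here, every measured step changes the group on the sulfur, as a 2.8-fold lower number from compound 1 to compound 3 (0.44 log units; beyond the scatter) also does, so no measured step bears on methoxy in place of bromo on an aromatic carbon. The expected step is therefore small and of uncertain direction, a 2.0-fold higher number from compound 2 to compound 4 (0.30 log units; within the scatter), with a wide range. Compound 4 is estimated at 2000 nM, between 500 nM and 8000 nM.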

Compound 4, concentration for 50% growth inhibition: 10000 nM
Beside the measured number, compound 4's estimate is 5.0-fold (0.70 log units) below it, and the stated range ends below it.
By their numbers in this assay, from the lowest: compound 2; then compounds 3 and 4 (each within the scatter of the next); then compound 1.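

Until now, only changes to the group on the sulfur had been seen to shift the number. Replacing 4-bromophenyl with 4-methoxyphenyl shows that this ring position matters too, giving a 10-fold higher number from compound 2 to compound 4 (1.00 log units; beyond the scatter) in this assay, with growth inhibition clearly weakened. No measurement shown here explains the loss.

Only bromo and methoxy are shown at this position, leaving it unclear whether the loss reflects bromo leaving or methoxy entering. An amine, a carboxylic acid or a simple hydrogen there could help separate the two, and the same change on compound 3 would test whether the step carries over.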